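Coumarin-type amides at the A3 receptor: compound 4 outlook

The source may report more compounds than this note shows. Statements on the series, on what has been measured and on what is new or still open speak of the compounds shown alone.

Measured compounds and values:
- Compound 1 `COCCNC(=O)c1cc2cccc(OC)c2oc1=O`: 0%
- Compound 2 `COc1cccc2cc(C(=O)Nc3c(C#N)ncn3-c3ccc(C#N)cc3)c(=N)oc12`: 1%
- Compound 3 `N=c1oc2ccc(Br)cc2cc1C(=O)NCCO`: 0%

In an assay on HeLa cells for displacement of a labelled ligand from adenosine receptor A3 (Homo sapiens), read by scintillation counting, with a stated time of 180 min, tested at 10 uM (on this read-out higher numbers stand for more inhibition at the one concentration tested (going by the name of the read-out) and lower numbers for less inhibition), compound 3 gives 0%, level with compound 1 at the digits shown; together they are the lowest of the three numbers, and compound 2 sits within the scatter of both. None of these three values separates from the others beyond the scatter.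

Compound 4 `N=c1oc2ccc(Br)cc2cc1C(=O)NC1CCCC1` is not yet measured. It differs from compound 3 by cyclopentyl in place of 2-hydroxyethyl on an amide-type nitrogen. Going by the values given here, no step between measured compounds is available to judge this change, and every measured value so far sits near the bottom of the scale. For compound 4 the expected step is a number 3 percentage points higher from compound 3 to compound 4 (within the scatter), which is no change beyond the scatter. Compound 4 is estimated at 3%, with a range from -8% to 20%.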

Compound 4, a percentage reported as inhibition, at one concentration (the size of the read-out at that concentration, not a potency): 0%
Compound 4: the middle estimate sits 3 percentage points above what was measured, and the stated range covers the measured number.
By their numbers in this assay, from the lowest: compounds 1, 3, 4 and 2 (each within the scatter of the next).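

In this assay the first step readable at this position, cyclopentyl in place of 2-hydroxyethyl on an amide-type nitrogen, gives no change at the digits printed from compound 3 to compound 4 (within the scatter) and leaves the number at the bottom of the scale. On the shared core, neither the hydrogen-bond donor and acceptor of 2-hydroxyethyl nor the carbon-only five-membered ring of cyclopentyl gives a readable signal. Nothing at hand explains this result.

Still open, as far as these compounds go, is whether a benzyl group, a longer alkyl chain, an amine or a carboxylic acid on this nitrogen would lift the number. With both compounds this low, this single step cannot show how such groups would compare.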